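A few compounds are considered here, and "the series" means these few. Any claim that something is new, unique, unknown or untested is made for them only; others in the source may bear on it.

Three esters sharing one core have been tested in a functional assay on PC-3 cells (Homo sapiens) for antiproliferative activity, read by sulforhodamine B assay, with a stated time of 48 h, tested at 50 uM; on this read-out higher numbers stand for more inhibition at the one concentration tested (going by the name of the read-out) and lower numbers for less inhibition. Compound 1, `CC1=CC[C@H](C(C)C)c2cc(C)c(OC(=O)c3ccc(C)cc3)cc21`, gives 49.6%. Compound 2, `CC1=CC[C@H](C(C)C)c2cc(C)c(OC(=O)c3ccc(C(F)(F)F)cc3)cc21`, gives 12.3%, and compound 3, `CC1=CC[C@H](C(C)C)c2cc(C)c(OC(=O)c3cccc(C(F)(F)F)c3)cc21`, gives 25.4%. Compound 2 and compound 1 differ in one place, (methyl in place of trifluoromethyl on an aromatic carbon), and that change made a number 37.3 percentage points higher from compound 2 to compound 1 (beyond the scatter). The difference between the cores of compound 2 and compound 3 is not broken down here. Compound 4, `CC1=CC[C@H](C(C)C)c2cc(C)c(OC(=O)c3cccc(C)c3)cc21`, has not been measured; it differs from compound 3 by methyl in place of trifluoromethyl on an aromatic carbon. This is the same kind of change as before, yet not the same: there the group sat para to a large group, here it sits meta to a large group. Because the earlier step gave a number 37.3 percentage points higher from compound 2 to compound 1 (beyond the scatter), a rise of roughly similar size is expected here, a number 29.6 percentage points higher from compound 3 to compound 4 (beyond the scatter), with a somewhat smaller one possible given the different place. Compound 4 is therefore estimated at 55%, expected between 30% and 75%.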

Compound 4, a percentage reported as inhibition, at one concentration (the size of the read-out at that concentration, not a potency): 38.6%
Estimate against measurement, compound 4: 16.4 percentage points above, within the range that was stated.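

Putting methyl in place of trifluoromethyl gave a number 13.2 percentage points higher from compound 3 to compound 4 (beyond the scatter) and so raised the number on both cores, but the size of the rise did not carry over: the same change on two cores in this assay, a number 37.3 percentage points higher (beyond the scatter) from compound 2 to compound 1 and a number 13.2 percentage points higher (beyond the scatter) from compound 3 to compound 4, 24.1 percentage points apart, beyond the scatter of two such steps

The direction therefore held across these two pairs, while a size read on one core cannot simply be transferred to the other; two pairs are too few to make a rule, and they do not show why the sizes differ. Putting 3-methylphenyl in place of 4-methylphenyl gave a number 11 percentage points lower from compound 1 to compound 4 (beyond the scatter) and so the place of the methyl also matters in this pair.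

The compounds shown leave open how other groups, such as chlorine, a methoxy group or an amine, would behave on this ring.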